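The source may hold more compounds than are shown below. What is called first, only, known or untested is meant among the compounds shown, and "the series" means these compounds.

Compounds measured so far:

Compound 1, `C=CCSc1nc2nc(C)cc(N3CC[C@@H](C)[C@@H](N(C)c4ncnc5[nH]ccc45)C3)n2n1`: 32600 nM
Compound 2, `Cc1cc(N2CC[C@@H](C)[C@@H](N(C)c3ncnc4[nH]ccc34)C2)n2nc(SCc3ccc(Cl)cc3)nc2n1`: 16000 nM
Compound 3, `Cc1cc(N2CC[C@@H](C)[C@@H](N(C)c3ncnc4[nH]ccc34)C2)n2nc(SCc3ccc(Br)cc3)nc2n1`: 4020 nM

All three share one core and differ only in the group on a saturated chain carbon bound to a sulfur. In a functional assay on MGC-803 cells (Homo sapiens) for inhibition, read by MTT assay, with a stated time of 72 h (on this read-out higher numbers stand for weaker inhibition and lower numbers for stronger inhibition), compound 3 gives the lowest number of the three; its nearest neighbour is compound 2, and the furthest is compound 1. Both steps toward compound 3 point the same way: an 8.1-fold lower number from compound 1 to compound 3 (0.91 log units; beyond the scatter), and a 4.0-fold lower number from compound 2 to compound 3 (0.60 log units; beyond the scatter), with a 2.0-fold lower number from compound 1 to compound 2 (0.31 log units; beyond the scatter) making up the difference.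

Compound 4, `Cc1cc(N2CC[C@@H](C)[C@@H](N(C)c3ncnc4[nH]ccc34)C2)n2nc(SCc3csc4ccc(Cl)cc34)nc2n1`, has not yet been measured. It differs from compound 3 in one place: 5-chloro-1-benzothiophen-3-yl in place of 4-bromophenyl on a saturated chain carbon bound to a sulfur

For the measured compounds named here, no measured step exchanges one aromatic group for another aromatic group of a different ring system, so the bearing of the known steps is indirect. They show that an aromatic group on that chain carbon, in place of vinyl, brought a modest lowering, and that the halogen on it mattered. The group entering in compound 4 keeps a halogen and adds a second aromatic ring, so a modest step is expected in either direction, with the lower direction somewhat more likely. For compound 4 the estimate is 3000 nM, between 800 nM and 12000 nM, meaning an expected 1.3-fold lower number from compound 3 to compound 4 (0.13 log units; within the scatter).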

Compound 4, half-maximal inhibitory concentration: > 100000 nM
Compound 4: no number, only a limit; the forecaster's own chance of this, stated with the estimate: 5%; middle value at least 33-fold (1.52 log units) from the limit.
By their numbers in this assay, from the lowest: compound 3; then compound 2; then compound 1. At a limit, above all of these: compound 4.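

In this assay, compound 4 stands at a limit of the read-out and not at a number: the limit of > 100000 nM in this assay, at which 1 of the 4 values shown sits. Among the earlier compounds, every step at this position was modest, and both aromatic groups gave lower numbers than vinyl, but this change brings an at least 24-fold higher number from compound 3 to compound 4 (1.39 log units; beyond the scatter), a large step, along with an at least 6.2-fold higher number from compound 2 to compound 4 (0.79 log units; beyond the scatter) and an at least 3.0-fold higher number from compound 1 to compound 4 (0.48 log units; beyond the scatter). For the compounds shown here, the position on a saturated chain carbon bound to a sulfur is therefore far more sensitive to the kind of aromatic group than the earlier compounds showed: an aromatic group with a halogen does not by itself lower the number, and compound 4 goes against the pattern set by compound 2 and compound 3, even though compound 2 also carries a chloro group.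

The compounds shown do not separate the part played by the added five-membered ring with its sulfur from that of the changed point of attachment or of the exchange of bromo for chloro. A plain phenyl, a naphthyl group or a benzofuran ring at this position would bear on that question, and so might a longer chain between the sulfur and the aromatic ring.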